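Amide-nitrogen aryl swap: compound 3 to compound 4

This account rests on a few compounds, and the source may have more. Where it says the series, first, only, none or still open, it means among the compounds named here.

Measured compounds in a functional assay on a cell-free system (plasma) with sterol O-acyltransferase, Soat (Rattus norvegicus) as the target; a lower number here means that less compound is needed, a higher number that more compound is needed for the effect:
Compound 1 `Cc1cc(C)c(NC(=O)N(Cc2cc(-c3ccccc3)cs2)C2CCCCCC2)c(C)c1` gives < 1 mg/kg, which is a limit.
Compound 2 `O=C(Nc1c(F)cc(F)cc1F)N(Cc1cccc(-c2cc[nH]n2)c1)C1CCCCCC1` gives 0.062 mg/kg.
Compound 3 `O=C(Nc1c(F)cc(F)cc1F)N(Cc1ccc(F)cc1)Cc1cccc(-c2cc[nH]n2)c1` gives < 0.32 mg/kg, which is a limit.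

Compound 3 therefore stands at the limit named in the limit of < 0.32 mg/kg in this assay, at which 1 of the 3 values shown sits, not at a number, and the step that the limit leaves unreadable from compound 2 to compound 3 is unreadable. Compound 4 `CSc1cc(C)nc(SC)c1NC(=O)N(Cc1ccc(F)cc1)Cc1cccc(-c2cc[nH]n2)c1` differs from compound 3 by a group of 11 heavy atoms (8 carbon, 1 nitrogen, 2 sulfur; one six-membered aromatic ring with 1 hetero atom) in place of a group of 9 heavy atoms (6 carbon, 3 fluorine; one six-membered aromatic ring of carbon only), on an amide-type nitrogen. For the measured compounds named here, none of the measured steps touches the group on this amide-type nitrogen, so no expectation beyond the scatter can be drawn from them. The step that the limit leaves unreadable from compound 3 to compound 4 is therefore estimated as small, in either direction. Compound 4 is expected to give 0.2 mg/kg in this assay, with a range from 0.04 mg/kg to 1 mg/kg.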

Compound 4, dose for half-maximal effect: < 0.1 mg/kg
Compound 4: only a limit was reported (the forecaster's own chance of this, stated with the estimate: 30%); at least 2.0-fold (0.30 log units) between middle value and limit.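

In this assay compound 3 gives only a limit, < 0.32 mg/kg. For the compounds shown here, compound 4 also gives only a limit, < 0.1 mg/kg, so no step from compound 3 to compound 4 can be read. The compounds shown leave open whether replacing 2,4,6-trifluorophenyl on the amide-type nitrogen changes the dose needed, and by how much.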